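Pentyloxy to Benzyloxy: an Expected Step in Inhibition

The compounds below may be only part of what the source reports. "The series", "measured", "known", "first", "only" and "open" are said of these compounds alone.

compound 1: `CC(C)CCOc1ccccc1C1CC(=O)c2ccccc2O1`, 43.6%
compound 2: `CCCCCOc1ccccc1C1CC(=O)c2ccccc2O1`, 40.1%

In a functional assay on J774.A1 cells (Mus musculus) for inhibition, read by immunoassay, with a stated time of 12 h, tested at 30 uM (a lower number here means less inhibition, a higher number more inhibition at the concentration tested (going by the name of the read-out)), compound 2 gives 40.1%, and compound 1 gives 43.6%; the step of a number 3.5 percentage points lower from compound 1 to compound 2 (within the scatter) lies within the scatter, so compound 2 stands alongside compound 1 rather than apart from it. Compound 3, `O=C1CC(c2ccccc2OCc2ccccc2)Oc2ccccc21`, differs from compound 2 by phenyl in place of butyl on a saturated chain carbon bound to an oxygen on an aromatic ring. Going by the values given here, the only measured step, a number 3.5 percentage points lower from compound 1 to compound 2 (within the scatter), alters the chain further out and gives little guidance here. Compound 3 is therefore expected to show a step of a number 1.9 percentage points higher from compound 2 to compound 3 (within the scatter), with no direction beyond the scatter. The estimate for compound 3 in this assay is 42%, within 20% to 64%.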

Compound 3, a percentage reported as inhibition, at one concentration (the size of the read-out at that concentration, not a potency): 91.5%
Beside the measured number, compound 3's estimate is 49.5 percentage points below it, outside the stated range (above it).
By their numbers in this assay, from the lowest: compounds 2 and 1 (each within the scatter of the next); then compound 3.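

In this assay, the place on a saturated chain carbon bound to an oxygen on an aromatic ring proves sensitive to the group it carries: phenyl in place of butyl gives a number 51.4 percentage points higher from compound 2 to compound 3 (beyond the scatter), and phenyl in place of isobutyl gives a number 47.9 percentage points higher from compound 1 to compound 3 (beyond the scatter). The two saturated chains showed no such separation, whereas the aromatic ring sets compound 3 apart from both. Nothing measured here explains this rise. Going by these compounds, it remains open whether a cyclohexyl group at this place would match phenyl, and whether a phenethyl group, with a longer chain before the ring, would keep the effect.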